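A few compounds are considered here, and "the series" means these few. Any claim that something is new, unique, unknown or untested is made for them only; others in the source may bear on it.

Measured in an ADME assay on L02 cells (Homo sapiens) for cytotoxicity, read by CCK-8 assay, with a stated time of 6 days; a lower number here means a stronger inhibitor, a higher number a weaker inhibitor:
- compound 1 `C[C@@H](Cn1ccc(-c2ccc(C#N)c(Cl)c2)n1)Nc1ccncc1`: "not determined" (no result reported)
- compound 2 `Cc1ccnc(N[C@@H](C)Cn2ccc(-c3ccc(C#N)c(Cl)c3)n2)n1`: > 30000 nM

For compound 2, > 30000 nM is a limit of the assay and not a number. Among the measured compounds shown here, this leaves the series without a numerical value so far, and no step between measured compounds is available.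

Compound 3 `C[C@@H](Cn1ccc(-c2ccc(C#N)c(Cl)c2)n1)Nc1ncnc2nc[nH]c12` differs from compound 2 on an amine nitrogen: a group of 9 heavy atoms (5 carbon, 4 nitrogen; one five-membered aromatic ring with 2 hetero atoms, one six-membered aromatic ring with 2 hetero atoms) in place of a group of 7 heavy atoms (5 carbon, 2 nitrogen; one six-membered aromatic ring with 2 hetero atoms), on an amine nitrogen.

No shift beyond the usual scatter is expected in this assay, in either direction. The expected step is a number no higher from compound 2 to compound 3 (the limit leaves the size open). Compound 3 is estimated at 30000 nM, with an expected range of 12000 nM to 80000 nM.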

Compound 3, half-maximal inhibitory concentration: 27900 nM
The estimate for compound 3 lay 1.1-fold (0.03 log units) above the measured number, within the range that was stated.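

In this assay, among the compounds shown here, compound 3 gives 27900 nM as the first true number of the series, with the 4-methylpyrimidin-2-yl group replaced on the amine nitrogen by a fused group of a five-membered and a six-membered aromatic ring. The change reads as an at least 1.0-fold lower number from compound 2 to compound 3 (0.03 log units; that floor lies within the scatter) and so sets only a floor. Compound 2 reads > 30000 nM which is a limit and not a number, and the true size of the step stays unread because of it: the limit of > 30000 nM in this assay, at which 1 of the 3 values shown sits.

Open, going by these compounds, is how a phenyl or an acetyl on the amine nitrogen would read in this assay and whether any group at this place gives a clearly lower number than compound 3.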